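The source may report more compounds than this note shows. Statements on the series, on what has been measured and on what is new or still open speak of the compounds shown alone.

Working notes on the series. Compound 1 `COc1ccc(-c2c[nH]c(=O)n2-c2cc(OC)c(OC)c(OC)c2)cc1` carries no single number in a functional assay on Bel-7402 cells (Homo sapiens) for cytotoxicity, read by MTT assay, with a stated time of 48 h; on this read-out lower numbers stand for stronger inhibition and higher numbers for weaker inhibition; compound 1 is reported there as "not determined" (no result reported). Within the data shown here, the only further value is a limit. Compound 2 `COc1ccc(-c2c[nH]c(=O)n2-c2cc(OC)c(OC)c(OC)c2)cc1N` sits at > 50000 nM in this assay, which is a limit of the assay and not a number, noted as the limit of > 50000 nM in this assay, at which 1 of the 2 values shown sits. The step to follow leads to compound 3 `COc1ccc(-c2cn(C(C)=O)c(=O)n2-c2cc(OC)c(OC)c(OC)c2)cc1`, not yet measured, which differs from compound 1 by acetyl in place of hydrogen on an aromatic nitrogen. No measured step between two compounds of this series is shown, so no direction or size of the step can be drawn from data; the expectation for this assay is a step of no size beyond the usual scatter. Among the measured compounds shown here, the one measured value is the limit of compound 2, > 50000 nM, and the series so far reads as weak. Compound 3 is estimated at 25000 nM, expected to fall between 4000 nM and 50000 nM.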

Compound 3, half-maximal inhibitory concentration: 9500 nM
Compound 3: middle estimate off by 2.6-fold (0.42 log units), on the high side; measured number inside the range.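

Among these compounds, compound 3 gives 9500 nM in this assay, but compound 1 carries no single number there, so no step between compound 1 and compound 3 can be read. From the compounds shown here alone, whether acetyl in place of hydrogen on the aromatic nitrogen shifts the value, and in which direction, stays open.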